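Extending the butyl chain on the piperazine nitrogen

This account rests on a few compounds, and the source may have more. Where it says the series, first, only, none or still open, it means among the compounds named here.

Compound 1 `CCOCCn1c(N2CCNCC2)nc2ccccc21` gives 11 nM in a functional assay on ileum for inhibition of histamine H1 receptor (Cavia porcellus); a higher number here means a weaker inhibitor, a lower number a stronger inhibitor. Compound 3 `CCCCN1CCN(c2nc3ccccc3n2CCOCC)CC1` gives 15 nM and stands highest of the two numbers, with compound 1 nearest, the two sitting within the scatter of each other, as a 1.4-fold higher number from compound 1 to compound 3 (0.13 log units; within the scatter) shows. For compound 2 `CCOCCn1c(N2CCN(c3ccccc3)CC2)nc2ccccc21` the assay reports only a limit, > 10000 nM. Compound 2 thus sits at the limit of > 10000 nM in this assay, at which 1 of the 3 values shown sits. The steps of an at least 900-fold higher number from compound 1 to compound 2 (2.95 log units; beyond the scatter) and an at least 660-fold lower number from compound 2 to compound 3 (2.82 log units; beyond the scatter) are the large ones in this set.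

Compound 4 `CCCCCN1CCN(c2nc3ccccc3n2CCOCC)CC1` differs from compound 3 by methyl in place of hydrogen on a saturated chain carbon, four bonds along the chain from an amine nitrogen in a ring, which reads as butyl to pentyl on that nitrogen. The step that bears on it is the alkylation from compound 1 to compound 3, which was a 1.4-fold higher number from compound 1 to compound 3 (0.13 log units; within the scatter) and stayed within the scatter; the phenyl step is of another kind. Lengthening the chain by one carbon is therefore expected to give no change beyond the scatter, a step of a 1.2-fold higher number from compound 3 to compound 4 (0.08 log units; within the scatter). Compound 4 is estimated at 18 nM, between 6 nM and 55 nM.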

Compound 4, half-maximal inhibitory concentration: 30 nM
For compound 4 the middle estimate is 1.7-fold (0.22 log units) below the measured one; the range from low to high includes it.
By their numbers in this assay, from the lowest: compounds 1, 3 and 4 (each within the scatter of the next, the first and the last beyond it). At a limit, above all of these: compound 2.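

For the compounds shown here, the step of a 2.0-fold higher number from compound 3 to compound 4 (0.30 log units; within the scatter) stays within the scatter in this assay, yet pentyl is the first chain on this nitrogen to separate from the unsubstituted amine, as a 2.7-fold higher number from compound 1 to compound 4 (0.44 log units; beyond the scatter) shows. Pentyl also stays far from the phenyl compound, with an at least 330-fold lower number from compound 2 to compound 4 (2.52 log units; beyond the scatter). Compound 2 still stands at a limit, not a number: the limit of > 10000 nM in this assay, at which 1 of the 4 values shown sits.

The compounds shown leave open whether a hexyl or longer chain on this nitrogen would move the number further from that of the unsubstituted amine. They also leave open whether a benzyl group, which sets a methylene between the nitrogen and the phenyl ring, would behave like the alkyl chains or like phenyl.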